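Methylsulfonyl in place of (2-phenylethenyl)carbonyl, second occurrence

The compounds below may be only part of what the source reports. "The series", "measured", "known", "first", "only" and "open" are said of these compounds alone.

Compound 1 `CN1CCN(c2ccc(C3=NN(C(=O)/C=C/c4ccccc4)C(c4ccc(N(C)C)cc4)C3)cc2)CC1` is the reference point of this small set; in a functional assay on HCC1806 cells (Homo sapiens) for inhibition, read by sulforhodamine B assay, tested at 10 uM (a lower number here means less inhibition, a higher number more inhibition at the concentration tested (going by the name of the read-out)), compound 1 gives 71%. Compound 2 `CN1CCN(c2ccc(C3=NN(S(C)(=O)=O)C(c4ccc(N(C)C)cc4)C3)cc2)CC1` carries methylsulfonyl in place of (2-phenylethenyl)carbonyl on an amine nitrogen in a ring and in this assay compound 2 gives -18.5%, a step of a number 89.5 percentage points lower from compound 1 to compound 2 (beyond the scatter). Compound 3 `CN(C)c1ccc(C2CC(c3ccc(-n4cncn4)cc3)=NN2C(=O)/C=C/c2ccccc2)cc1` differs from compound 1 by 1H-1,2,4-triazol-1-yl in place of 4-methylpiperazin-1-yl on an aromatic carbon, which is the whole of the difference between the two cores; in this assay compound 3 gives -3.7%, a step of a number 74.7 percentage points lower from compound 1 to compound 3 (beyond the scatter). Compound 3 thus stands second of the three numbers, far under compound 1 and above compound 2.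

Compound 4 `CN(C)c1ccc(C2CC(c3ccc(-n4cncn4)cc3)=NN2S(C)(=O)=O)cc1` is not yet measured. It differs from compound 3 by methylsulfonyl in place of (2-phenylethenyl)carbonyl on an amine nitrogen in a ring. The change is the same kind of change as that from compound 1 to compound 2 and occurs twice among the compounds shown; the surroundings are not identical, since the ring atom two ring bonds from the place bears a 4-(1H-1,2,4-triazol-1-yl)phenyl group in compound 3 and a large group in compound 1.

The first occurrence of the change took away nearly all inhibition, but compound 3 already stands near zero, so little room remains downward. The expected step is a number 8.3 percentage points lower from compound 3 to compound 4 (within the scatter), much smaller than the earlier one, resting on compound 3 at -3.7% and on the earlier step of a number 89.5 percentage points lower from compound 1 to compound 2 (beyond the scatter). Compound 4 is estimated at -12%, between -30% and 8%.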

Compound 4, a percentage reported as inhibition, at one concentration (the size of the read-out at that concentration, not a potency): 10.8%
Compound 4: the middle estimate sits 22.8 percentage points below what was measured; measured number outside the range, above it.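

In this assay, methylsulfonyl in place of (2-phenylethenyl)carbonyl gives a number 14.5 percentage points higher from compound 3 to compound 4 (beyond the scatter), so the large loss seen on the core of compound 1 does not carry over to the core of compound 3: the same change on two cores in this assay, a number 89.5 percentage points lower (beyond the scatter) from compound 1 to compound 2 and a number 14.5 percentage points higher (beyond the scatter) from compound 3 to compound 4, 104 percentage points apart, beyond the scatter of two such steps

The same square read the other way gives a number 29.3 percentage points higher from compound 2 to compound 4 (beyond the scatter) for 1H-1,2,4-triazol-1-yl in place of 4-methylpiperazin-1-yl, so in this series the effect of either change depends on the group held at the other place: the same change on two cores in this assay, a number 74.7 percentage points lower (beyond the scatter) from compound 1 to compound 3 and a number 29.3 percentage points higher (beyond the scatter) from compound 2 to compound 4, 104 percentage points apart, beyond the scatter of two such steps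

This does not show why the steps differ, and with one pair on each core, tested at a single concentration in one cell line, it gives no rule for any further core.

Still open, as far as these compounds go, is whether the inhibition of compound 1 is tied to 4-methylpiperazin-1-yl itself or would also appear with another amine on that aromatic carbon, such as morpholin-4-yl or a piperazine without the methyl, or with a carboxylic acid there. Also open, from the compounds shown here alone, is how other groups on the ring nitrogen would behave, such as a plain acetyl or a saturated 3-phenylpropanoyl, which would separate the double bond of (2-phenylethenyl)carbonyl from its phenyl ring and carbonyl.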